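Bis-furan amidines: chloro in place of methoxy

A few compounds are considered here, and "the series" means these few. Any claim that something is new, unique, unknown or untested is made for them only; others in the source may bear on it.

Compound 2 `COc1ccc(-c2ccc(-c3ccc(C(=N)N)o3)o2)cc1` stands at the lower of the two numbers in a functional assay on MCF7 cells (Homo sapiens) for inhibition, read by sulforhodamine B assay, with a stated time of 48 h (a higher number here means a weaker inhibitor of growth, a lower number a stronger inhibitor of growth), giving 330 nM. Compound 1 `N=C(N)c1ccc(-c2ccc(-c3cc(Cl)cc(Cl)c3)s2)s1` gives 1340 nM in this assay, a gap beyond the scatter. Compound 3 `N=C(N)c1ccc(-c2ccc(-c3ccc(Cl)cc3)o2)o1` is not yet measured; it differs from compound 2 by chloro in place of methoxy on an aromatic carbon. For the measured compounds named here, no measured pair covers this change, so only a small step is expected: the estimated step is a 1.5-fold higher number from compound 2 to compound 3 (0.18 log units; within the scatter), a slight move toward a higher number, and an outcome within the scatter would not surprise. Compound 3 is therefore expected at 500 nM, with a range from 150 nM to 1600 nM.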

Compound 3, concentration for 50% growth inhibition: 1270 nM
Estimate against measurement, compound 3: 2.5-fold (0.40 log units) below, and the stated range covers the measured number.
By their numbers in this assay, from the lowest: compound 2; then compounds 3 and 1 (each within the scatter of the next).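

On the six-membered aromatic ring, para to a large group, chloro in place of methoxy gives a 3.8-fold higher number from compound 2 to compound 3 (0.59 log units; beyond the scatter) in this assay. For the compounds shown here, this is the first step that can be read in one place, and it shows that this position responds to the change, with methoxy holding the lower number of the pair. No measurement shown here accounts for the step. Going by these compounds, whether an amine or a hydroxy group at this place would stand nearer to methoxy or to chloro remains open, as does whether the same exchange would give a similar step on the core of compound 1.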